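Ester variation on the shared core

The source may hold more compounds than are shown below. What is called first, only, known or untested is meant among the compounds shown, and "the series" means these compounds.

Compound 1 `CC/C=C\C[C@H]1C(=O)C=C[C@H]1CC(=O)OCCC` stands level with compound 3 `CC/C=C\C[C@H]1C(=O)C=C[C@H]1CC(=O)Oc1ccc(O)cc1` at the digits shown: in a functional assay on RAW264.7 cells (Mus musculus) for inhibition, read by ELISA, with a stated time of 24 h (a higher number here means that more compound is needed for the effect, a lower number that less compound is needed), compound 1 gives 23000 nM and compound 3 gives 23000 nM. Compound 2 `CC/C=C\C[C@H]1C(=O)C=C[C@H]1CC(=O)Oc1ccccc1` gives 33000 nM. The two changes made so far on the oxygen next to the carbonyl group stayed small: a 1.4-fold higher number from compound 1 to compound 2 (0.16 log units; within the scatter) and no change at the digits printed from compound 1 to compound 3 (within the scatter); likewise a 1.4-fold lower number from compound 2 to compound 3 (0.16 log units; within the scatter). Compound 4 `CC/C=C\C[C@H]1C(=O)C=C[C@H]1CC(=O)OC1CCCCC1` differs from compound 1 in one place: cyclohexyl in place of propyl on an oxygen next to a carbonyl group. Both measured steps that bear on this replaced propyl on that oxygen without moving the number beyond the scatter, so no step beyond the scatter is expected in this assay here either. Compound 4 is therefore estimated at 23000 nM, range 10000 nM to 50000 nM, meaning an expected no change at the digits printed from compound 1 to compound 4 (within the scatter).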

Compound 4, half-maximal effective concentration: 22000 nM
Compound 4: the middle estimate sits 1.0-fold (0.02 log units) above what was measured; low and high end bracket the measured number.
By their numbers in this assay, from the lowest: compounds 4, 1, 3 and 2 (each within the scatter of the next).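

In this assay the step to cyclohexyl on an oxygen next to a carbonyl group reads a 1.0-fold lower number from compound 1 to compound 4 (0.02 log units; within the scatter) and a 1.0-fold lower number from compound 3 to compound 4 (0.02 log units; within the scatter) and a 1.5-fold lower number from compound 2 to compound 4 (0.18 log units; within the scatter) so a non-aromatic ring now joins the open chain and the aromatic rings without separating from them. Across propyl, phenyl, 4-hydroxyphenyl and cyclohexyl, neither the added heavy atoms nor the type of ring gives a step beyond the scatter. Nothing at hand accounts for this flat result.

As far as these compounds go, whether a longer chain, an amine or a carboxylic acid on this oxygen would move the number remains open. From the compounds shown here alone, the shared core stays the same throughout, so what changes there would do is also open.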